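The source may hold more compounds than are shown below. What is called first, only, known or untested is meant among the compounds shown, and "the series" means these compounds.

Within the data shown here, in a functional assay on HeLa cells (Homo sapiens) for antiproliferative activity, read by MTT assay, with a stated time of 72 h (a lower number here means a stronger inhibitor, a higher number a weaker inhibitor), compound 1 `COc1ncc(-c2ccc3c(c2)N(c2ccc(F)cc2)C(=O)CO3)cc1NS(=O)(=O)c1ccc(F)cc1` gives 10500 nM and compound 2 `COc1ccc(N2C(=O)COc3ccc(-c4cnc(OC)c(NS(=O)(=O)c5ccc(F)cc5)c4)cc32)cc1` gives 1220 nM as the lower of the two numbers so far. Compound 3 `COc1ncc(-c2ccc3c(c2)N(c2ccc(Cl)cc2)C(=O)CO3)cc1NS(=O)(=O)c1ccc(F)cc1` brings the change chloro in place of methoxy on an aromatic carbon to compound 2, which reads as 4-methoxyphenyl to 4-chlorophenyl. Among the measured compounds shown here, only one measured step bears on this change. The step of an 8.6-fold lower number from compound 1 to compound 2 (0.93 log units; beyond the scatter) is methoxy in place of fluoro on the same aromatic ring, and it lies beyond the scatter. For the measured compounds named here, compound 3 loses that methoxy, and no chloro compound has been measured, so the fluoro compound is the only guide. A rise in this assay somewhat smaller than that step is expected. The expected change is a 4.1-fold higher number from compound 2 to compound 3 (0.61 log units; beyond the scatter) toward a higher number. For compound 3 the estimated value is 5000 nM with an expected range from 1800 nM to 12000 nM as working figures.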

Compound 3, half-maximal inhibitory concentration: 4830 nM
The estimate for compound 3 lay 1.0-fold (0.02 log units) above the measured number; the range from low to high includes it.
By their numbers in this assay, from the lowest: compound 2; then compound 3; then compound 1.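

At this position on the aromatic ring in this assay, a 4.0-fold higher number from compound 2 to compound 3 (0.60 log units; beyond the scatter) and a 2.2-fold lower number from compound 1 to compound 3 (0.34 log units; beyond the scatter) both lie beyond the scatter, so chloro sets compound 3 apart from both the methoxy and fluoro compounds. The three groups now rank by lower number as methoxy, then chloro, then fluoro, which shows that the read-out also responds to exchanging one halogen for another, not only to removing methoxy. No supporting measurement is available to explain this order.

Three groups at one position do not show whether the order extends to an amine, a hydroxyl or a longer chain such as ethoxy. From the compounds shown here alone, all three compounds share the rest of the structure, so it remains open whether the same order holds when another part of the shared core changes.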